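From a thiazolyl group to an open chain

The source may hold more compounds than are shown below. What is called first, only, known or untested is meant among the compounds shown, and "the series" means these compounds.

- Compound 1 `CCC(C(=O)N[C@@H](CC(=O)O)C(=O)CNCN1CCC(Cc2ccccc2)CC1)n1ccnc(NCc2nonc2C)c1=O` gives 1.62 nM 
- Compound 2 `CCC(C(=O)N[C@@H](CC(=O)O)C(=O)CSCc1ccccc1)n1ccnc(NCC2COc3ccccc3O2)c1=O` gives 30 nM 
- Compound 3 `CCC(C(=O)N[C@@H](CC(=O)O)C(=O)CSCc1ccccc1)n1ccnc(NCc2cncs2)c1=O` gives 3.42 nM 

In a functional assay on NT2 cells (Homo sapiens) for inhibition (on this read-out higher numbers stand for weaker inhibition and lower numbers for stronger inhibition), compound 3 holds the middle place of the three, with compound 1 somewhat lower and compound 2 clearly higher. Compound 4 `CCC(C(=O)N[C@@H](CC(=O)O)C(=O)CSCc1ccccc1)n1ccnc(NCCCOC)c1=O` changes one group of compound 3: 2-methoxyethyl in place of 1,3-thiazol-5-yl on a saturated chain carbon bound to a nitrogen on an aromatic ring on a saturated chain carbon bound to a nitrogen on an aromatic ring. For the measured compounds named here, compound 1 differs from compound 3 in more than one place, so only one measured step bears on this change. It is an 8.8-fold lower number from compound 2 to compound 3 (0.94 log units; beyond the scatter) and it is modest, but it shows that this assay responds to a change of group here. Going by the values given here, both groups in that step contain a ring, so the data offer no direct example of an open chain at this place. A modest step toward a higher number therefore seems likely, though with wide uncertainty. The expected size is a 2.9-fold higher number from compound 3 to compound 4 (0.47 log units; beyond the scatter) in this estimate. For compound 4 the estimated value is 10 nM with an expected range from 3 nM to 35 nM in this assay.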

Compound 4, half-maximal inhibitory concentration: > 10 nM
Compound 4 was reported as a limit; the forecaster's own chance of this, stated with the estimate: 1%; the middle value sits exactly at the limit.
By their numbers in this assay, from the lowest: compound 1; then compound 3; then compound 2.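

Compound 4 carries no exact number, only a limit: the limit of > 10 nM in this assay, at which 1 of the 4 values shown sits.

Even so, replacing 1,3-thiazol-5-yl with 2-methoxyethyl gives an at least 2.9-fold higher number from compound 3 to compound 4 (0.46 log units; beyond the scatter), so inhibition in this assay weakens beyond the scatter. For the compounds shown here, this is the first case with no ring at this place on a saturated chain carbon bound to a nitrogen on an aromatic ring, and here the open chain does not match the thiazolyl group. The step from compound 2 to compound 4 cannot be read, so the open chain cannot be ranked against the 2,3-dihydro-1,4-benzodioxin-2-yl group.

Going by these compounds, how much weaker compound 4 really is remains open, as does whether the missing ring or the methoxy oxygen matters more. A plain propyl chain, or an amine at the chain end, could help separate these two possibilities.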